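The source may report more compounds than this note shows. Statements on the series, on what has been measured and on what is new or still open speak of the compounds shown alone.

compound 1 `CC(C)n1ncc2c(C(=O)Nc3ccccc3F)cc(-c3ccccn3)nc21` gives 100000 nM
compound 2 `CC(C)n1ncc2c(C(=O)Nc3ccc(F)cc3F)cc(-c3cccs3)nc21` gives > 200000 nM
compound 3 `CC(C)n1ncc2c(C(=O)Nc3ccc(F)cc3)cc(-c3ccco3)nc21` gives > 200000 nM

Among the compounds with values here, in an ADME assay on LLC-MK2 cells (Macaca mulatta) for cytotoxicity, read by spectrophotometry and crystal violet staining, with a stated time of 4 days (on this read-out lower numbers stand for higher toxicity in this test and higher numbers for lower toxicity in this test), compound 1 at 100000 nM holds the only true number of the three. Compound 2 at > 200000 nM shows a limit of the assay, not a number. Compound 3 at > 200000 nM likewise shows a limit.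

Compound 4 `CC(C)n1ncc2c(C(=O)Nc3ccccc3F)cc(-c3cncs3)nc21`, not yet measured, carries 1,3-thiazol-5-yl in place of pyridin-2-yl on an aromatic carbon, and the swap reads 1,3-thiazol-5-yl in place of pyridin-2-yl on an aromatic carbon in full. Within the data shown here, no measured pair isolates this swap, since compound 2 and compound 3 differ from compound 1 in more than one place. In this assay no shift beyond the usual scatter is therefore expected, starting from compound 1 at 100000 nM as the only anchor. The estimated step is a 1.1-fold higher number from compound 1 to compound 4 (0.04 log units; within the scatter) and stays small. For compound 4 the estimate is 110000 nM, with an expected range from 45000 nM to 220000 nM around it.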

Compound 4, half-maximal cytotoxic concentration: 100000 nM
Estimate against measurement, compound 4: 1.1-fold (0.04 log units) above; measured number inside the range.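

Within the data shown here, until now no pair differed in one place. Here, on the aromatic carbon next to the ring nitrogen, putting 1,3-thiazol-5-yl in place of pyridin-2-yl gives, in this assay, no change at the digits printed from compound 1 to compound 4 (within the scatter). So a five-membered aromatic ring with sulfur can stand at this place on the core of compound 1 without moving the read-out. Compound 2 and compound 3 each offer a limit, not a number: the limit of > 200000 nM in this assay, at which 2 of the 4 values shown sit.

Still open, going by these compounds, is whether a non-aromatic group at this place, such as an amine or a carboxylic acid, would leave the read-out equally unmoved.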